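Side-chain swap from compound 2 to compound 3

The compounds below may be only part of what the source reports. "The series", "measured", "known", "first", "only" and "open" are said of these compounds alone.

Measured so far:
compound 1 `CC(C)CCc1nn(CCC(C)C)c(=O)c(C2=NS(=O)(=O)c3cc(NS(C)(=O)=O)ccc3N2)c1O`: > 33000 nM (a limit)
compound 2 `CCC(C)(C)Cn1nc(-c2cccs2)c(O)c(C2=NS(=O)(=O)c3cc(NS(C)(=O)=O)ccc3N2)c1=O`: > 1000 nM (a limit)

Both readings in an ADME assay on Huh-7 cells (Homo sapiens) for cytotoxicity, with a stated time of 72 h (a higher number here means that more compound is tolerated, a lower number that less compound is tolerated), are limits and not numbers. Compound 2 stands only at a limit (> 1000 nM), and that is all that is known of it. For the measured compounds named here, the two compounds differ in more than one place, so no measured step is available for comparison.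

Compound 3 `COCCn1nc(-c2cccs2)c(O)c(C2=NS(=O)(=O)c3cc(NS(C)(=O)=O)ccc3N2)c1=O` is not yet measured. It carries methoxymethyl in place of 1,1-dimethylpropyl on a saturated chain carbon bound to an aromatic nitrogen. Cut one bond further out, the same difference reads 2,2-dimethylbutyl to 2-methoxyethyl.

Going by the values given here, the only guide to a higher ceiling is compound 1, whose reading is also a limit (> 33000 nM). An upward step in this assay is therefore expected, though its size is poorly constrained, and the estimated change is (a step that the limit leaves unreadable from compound 2 to compound 3). The estimated value for compound 3 is 10000 nM (expected range 1000 nM to 50000 nM).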

Compound 3, half-maximal cytotoxic concentration: > 1000 nM
Compound 3 was reported as a limit (the forecaster's own chance of this, stated with the estimate: 75%); the middle value is on the limit's open side.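

In this assay, compound 2 gives only a limit, > 1000 nM. Compound 3 also gives only a limit, > 1000 nM, so no step can be read between compound 2 and compound 3. The compounds shown leave open where either half-maximal cytotoxic concentration lies, and whether replacing 2,2-dimethylbutyl with 2-methoxyethyl changes it at all.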